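Furoyl thioimidazolidine acrylamides: amide to ketone step

This account rests on a few compounds, and the source may have more. Where it says the series, first, only, none or still open, it means among the compounds named here.

Measured compounds:
Compound 1 `N#C/C(=C\N1CCN(C(=O)c2ccco2)C1=S)C(=O)Nc1ccc(Cl)cc1` gives 25200 nM in a functional assay on OVCAR-4 cells (Homo sapiens) for inhibition, read by sulforhodamine B assay, with a stated time of 48 h; on this read-out higher numbers stand for weaker inhibition of growth and lower numbers for stronger inhibition of growth.
Compound 2 `N#C/C(=C\N1CCN(C(=O)c2ccco2)C1=S)C(N)=O` gives 18500 nM in this assay.

Compound 2 stands next to compound 1 on the two numbers shown: the change from compound 1 to compound 2 is a 1.4-fold lower number from compound 1 to compound 2 (0.13 log units; within the scatter), so the two cannot be told apart on this read-out. Compound 3 `N#C/C(=C\N1CCN(C(=O)c2ccco2)C1=S)C(=O)c1ccccc1` keeps the shared core and carries phenyl in place of amino on a carbonyl carbon. Among the compounds with values here, no measured step touches the carbonyl carbon; the only measured step, on the amide-type nitrogen, a 1.4-fold lower number from compound 1 to compound 2 (0.13 log units; within the scatter), lies within the scatter. That step bears on the new change only loosely, since it alters the same carbonyl-bearing arm. With nothing beyond scatter seen so far in this assay, compound 3 is expected to land near compound 2, with a step of a 1.1-fold higher number from compound 2 to compound 3 (0.03 log units; within the scatter). The estimate for compound 3 in this assay is 20000 nM, spanning 7000 nM to 60000 nM.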

Compound 3, concentration for 50% growth inhibition: 29800 nM
Estimate against measurement, compound 3: 1.5-fold (0.17 log units) below; the range from low to high includes it.
By their numbers in this assay, from the lowest: compounds 2, 1 and 3 (each within the scatter of the next).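

In this assay, within the data shown here, the first direct change at the carbonyl carbon, carbamoyl to benzoyl, gives a 1.6-fold higher number from compound 2 to compound 3 (0.21 log units; within the scatter), and phenyl in place of (4-chlorophenyl)amino on the same carbon gives a 1.2-fold higher number from compound 1 to compound 3 (0.07 log units; within the scatter). The amide and ketone forms of this arm therefore cannot be told apart on this read-out, whether the amide nitrogen is unsubstituted or carries 4-chlorophenyl, and all three compounds remain within the scatter of one another. No supporting data bear on why these changes leave the number within the scatter.

From the compounds shown here alone, it remains open whether any group on this carbonyl carbon can move the number beyond the scatter, such as a carboxylic acid, a methyl ketone or a morpholine amide. The furoyl group and the nitrile are constant across all three compounds, so their contribution cannot be read here.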